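Taking Fluorine Off a Pendant Ring: Does the Loss Repeat?

The compounds below may be only part of what the source reports. "The series", "measured", "known", "first", "only" and "open" are said of these compounds alone.

Compound 1 `Cc1ccc(CN2CCC(NC(=O)NCc3ccc(-c4ccc(F)cc4)cc3)CC2)cc1` and compound 2 `Cc1ccc(CN2CCC(NC(=O)NCc3ccc(-c4ccccc4)cc3)CC2)cc1` are built on one shared core. In an in vitro functional assay on HEK293 cells for antagonist activity at melanin-concentrating hormone receptor 1 (Homo sapiens), read by GTPgammaS binding, with a stated time of 45 min (on this read-out lower numbers stand for stronger inhibition and higher numbers for weaker inhibition), compound 1 gives 198 nM. Compound 2 carries a single alteration, (hydrogen in place of fluoro on an aromatic carbon), and in this assay compound 2 gives 1060 nM. That single swap produced a 5.4-fold higher number from compound 1 to compound 2 (0.73 log units; beyond the scatter), so for this pair the fluorine clearly helped.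

Compound 3 `CCC(CO)(CO)NC(=O)N(CCC1CCN(Cc2ccc(C)cc2)CC1)Cc1ccc(-c2ccc(F)cc2)cc1` rests on a different core; the difference between the two cores is not broken down here. In this assay compound 3 gives 293 nM, close to compound 1 and well apart from compound 2.

Compound 4 `CCC(CO)(CO)NC(=O)N(CCC1CCN(Cc2ccc(C)cc2)CC1)Cc1ccc(-c2ccccc2)cc1` has not yet been tested. It stands to compound 3 exactly as compound 2 stands to compound 1: hydrogen in place of fluoro on an aromatic carbon, at the same place in the same kind of ring. Within the data shown here, the expectation is that the fluorine matters again, giving a step of about a 4.1-fold higher number from compound 3 to compound 4 (0.61 log units; beyond the scatter) in this assay, beside a 5.4-fold higher number from compound 1 to compound 2 (0.73 log units; beyond the scatter), because compound 3 starts near 293 nM and the only known precedent points to a weaker result. Compound 4 is therefore estimated at 1200 nM, plausibly between 450 nM and 3200 nM.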

Compound 4, antagonist equilibrium constant: 147 nM
Estimate against measurement, compound 4: 8.2-fold (0.91 log units) above, and the stated range ends above it.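

In this assay, the loss seen on the first core does not repeat: on the core of compound 3, the same swap of fluoro for hydrogen gives a 2.0-fold lower number from compound 3 to compound 4 (0.30 log units; within the scatter) and so leaves compound 3 and compound 4 indistinguishable. The effect of this change therefore did not carry from one core to the other, and the two steps differ by more than ordinary measurement scatter would allow: the same change on two cores in this assay, a 5.4-fold higher number (0.73 log units; beyond the scatter) from compound 1 to compound 2 and a 2.0-fold lower number (0.30 log units; within the scatter) from compound 3 to compound 4, 11-fold (1.03 log units) apart, beyond the scatter of two such steps. These two pairs show the size of that gap but not its cause, and they say nothing about how any other change would behave on these two cores.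

The compounds shown do not separate the parts in which the two cores differ, so it remains open which of those parts accounts for the different outcomes. From the compounds shown here alone, it is also open whether a chlorine or a methoxy group, placed para to the same large group, would give matching steps on both cores.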